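Lengthening the Ethoxy Group of Compound 1

This account rests on a few compounds, and the source may have more. Where it says the series, first, only, none or still open, it means among the compounds named here.

Among the measured compounds shown here, compound 1 `CCOC(=O)C(=O)Nc1cccccc1=O` is the strongest of the three compounds measured so far in a functional assay on the whole organism (strain Sprague-Dawley CD) for inhibition, with Rattus norvegicus as the target, read by paw edema, at a dose of 30 mg/kg by the oral route (on this read-out higher numbers stand for a stronger effect at the one dose given and lower numbers for a weaker effect), where compound 1 gives 79%. The other two share its core and differ from it on an aromatic carbon. Compound 2 `CCOC(=O)C(=O)Nc1ccccc(NC)c1=O` gives 0%, and the step of a number 79 percentage points lower from compound 1 to compound 2 (beyond the scatter). Compound 3 `CCOC(=O)C(=O)Nc1ccc(NC(=O)C(=O)OCC)c(=O)cc1` gives 61%, with a number 18 percentage points lower from compound 1 to compound 3 (beyond the scatter). Both measured steps therefore sit on an aromatic carbon, and both weaken the effect, the first one completely.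

Compound 4 `CCCCCOC(=O)C(=O)Nc1cccccc1=O` changes a different part of the molecule: propyl in place of hydrogen on a saturated chain carbon, two bonds along the chain from an oxygen next to a carbonyl group. The same difference, cut one bond further out, reads ethoxy to pentyloxy, so everything on the aromatic carbons stays exactly as in compound 1. Neither measured step touches this chain, so there is no direct guide to the size of the change; the measured steps only show that the untouched core of compound 1 supports a strong effect. With nothing to point either way, the expected step of a number 9 percentage points lower from compound 1 to compound 4 (within the scatter) is small, most likely within the scatter, with the uncertainty spread to both sides. Compound 4 is therefore estimated at 70%, in a range from 40% to 90%.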

Compound 4, a percentage reported as inhibition, in the whole organism at one dose (the size of the read-out at that dose, not a potency): 12%
For compound 4 the middle estimate is 58 percentage points above the measured one; measured number outside the range, below it.
By their numbers in this assay, from the lowest: compound 2; then compound 4; then compound 3; then compound 1.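

In this assay, the saturated chain proves to be far from a silent part of the molecule: going from ethoxy to pentyloxy, with everything on the aromatic carbons left as it was, comes with a number 67 percentage points lower from compound 1 to compound 4 (beyond the scatter) at the one dose given. Large losses are therefore not confined to the aromatic carbons, where compound 2 had shown one, and the strong effect of compound 1 depends on the length of this chain as well as on the state of those carbons. Nothing available here explains why the three added carbons cost so much of the effect.

Two measured chain lengths cannot show whether the effect fades gradually or drops suddenly as the chain grows, so a propoxy or butoxy chain would show where between ethoxy and pentyloxy the loss sets in, and a methoxy group would show whether a shorter chain keeps the effect of compound 1 or even adds to it. From the compounds shown here alone, it also remains open whether the end of the chain tolerates anything other than plain carbon, such as a carboxylic acid or an amine in place of the ethyl group.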